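The source may report more compounds than this note shows. Statements on the series, on what has been measured and on what is new or still open speak of the compounds shown alone.

Compound 2, `O=S(=O)(c1ccccc1)c1cnc2ccccc2c1N1CCCCCC1`, carries an azepan-1-yl group on the shared core. Going by the values given here, in an assay on isolated protein for displacement of a labelled ligand from metabotropic glutamate receptor 5 (Homo sapiens), with a stated time of 60 min, tested at 1 uM (on this read-out lower numbers stand for less inhibition and higher numbers for more inhibition at the one concentration tested (going by the name of the read-out)), compound 2 gives 79.9%, the higher of the two numbers measured so far. Among the compounds with values here, its only measured neighbour is compound 1, `CCN1CCN(c2c(S(=O)(=O)c3ccccc3)cnc3ccccc23)CC1`, which carries 4-ethylpiperazin-1-yl at the same aromatic carbon; in this assay compound 1 gives 1.7%. Within the data shown here, the single measured step, a number 78.2 percentage points higher from compound 1 to compound 2 (beyond the scatter), shows that the group at this position can shift the read-out a long way.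

Compound 3, `O=S(=O)(c1ccccc1)c1cnc2ccccc2c1N1CCCC1`, has not been measured. It differs from compound 2 by pyrrolidin-1-yl in place of azepan-1-yl on an aromatic carbon. Among the measured compounds shown here, the one measured step concerns a different exchange at this place, 4-ethylpiperazin-1-yl for azepan-1-yl, so it says only that a change here can be large, not how a seven-membered ring compares with a five-membered one. Because compound 2 gives 79.9% and compound 1 gives 1.7%, a downward step of uncertain size is expected, and the estimated step is a number 34.9 percentage points lower from compound 2 to compound 3 (beyond the scatter). The expected value for compound 3 in this assay is 45%, within 5% to 85%.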

Compound 3, a percentage reported as inhibition, at one concentration (the size of the read-out at that concentration, not a potency): 7.1%
For compound 3 the middle estimate is 37.9 percentage points above the measured one, and the stated range covers the measured number.
By their numbers in this assay, from the lowest: compounds 1 and 3 (each within the scatter of the next); then compound 2.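

In this assay the change from azepan-1-yl to pyrrolidin-1-yl on this aromatic carbon gives a number 72.8 percentage points lower from compound 2 to compound 3 (beyond the scatter), so the read-out here depends strongly on ring size alone. The earlier step exchanged azepan-1-yl for 4-ethylpiperazin-1-yl, which changed the ring's hetero atoms and added an ethyl group, whereas these two groups are both non-aromatic rings with 1 hetero atom and differ in size, seven-membered against five-membered. The remaining step, a number 5.4 percentage points higher from compound 1 to compound 3 (within the scatter), means that pyrrolidin-1-yl and 4-ethylpiperazin-1-yl cannot be told apart in this read-out, so among the three groups shown, only azepan-1-yl gives a high number.

No measurement at hand explains this sharp dependence on ring size. The compounds shown leave open where the six-membered piperidin-1-yl ring would fall between compound 2 and compound 3, and whether an open-chain amine such as diethylamino on the same carbon could match azepan-1-yl.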